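From 3-bromophenyl to 3,4,5-trimethoxyphenyl: working notes

This account rests on a few compounds, and the source may have more. Where it says the series, first, only, none or still open, it means among the compounds named here.

Measured in a functional assay on MCF7 cells (Homo sapiens) for cytotoxicity, read by MTT assay, with a stated time of 72 h; on this read-out lower numbers stand for stronger inhibition and higher numbers for weaker inhibition:
compound 1 `O=C(N/N=C/c1cccc(Br)c1)Nc1cc2c(Nc3ccc(F)c(Cl)c3)ncnc2cc1O[C@H]1CCOC1`: 12400 nM
compound 2 `COc1ccc(/C=N/NC(=O)Nc2cc3c(Nc4ccc(F)c(Cl)c4)ncnc3cc2O[C@H]2CCOC2)cc1`: 27300 nM

Of these two, compound 1 holds the lower number, 12400 nM, and so shows the stronger inhibition. The next compound to be tested is compound 3 `COc1cc(/C=N/NC(=O)Nc2cc3c(Nc4ccc(F)c(Cl)c4)ncnc3cc2O[C@H]2CCOC2)cc(OC)c1OC`, which carries this change from compound 1: 3,4,5-trimethoxyphenyl in place of 3-bromophenyl on a carbon with a double bond to nitrogen.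

Within the data shown here, only one measured step bears on this change: a 2.2-fold higher number from compound 1 to compound 2 (0.34 log units; beyond the scatter). It is modest, and it comes from 4-methoxyphenyl in place of 3-bromophenyl at the same place. Among the measured compounds shown here, no measurement yet covers the 3,4,5-trimethoxyphenyl group, so this support is thin. A modest step towards a higher number is therefore expected in this assay.

The expected step is a 2.0-fold higher number from compound 1 to compound 3 (0.30 log units; within the scatter). Compound 3 is estimated at 25000 nM, with an expected range of 10000 nM to 60000 nM.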

Compound 3, half-maximal inhibitory concentration: 26500 nM
Compound 3: the middle estimate sits 1.1-fold (0.03 log units) below what was measured; measured number inside the range.
By their numbers in this assay, from the lowest: compound 1; then compounds 3 and 2 (each within the scatter of the next).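

In this assay, the 3,4,5-trimethoxyphenyl group on this carbon gives a 2.1-fold higher number from compound 1 to compound 3 (0.33 log units; beyond the scatter) and leaves compound 1 with the lowest number of the three, so the move away from 3-bromophenyl now has the same direction with two different entering groups. Replacing 4-methoxyphenyl with 3,4,5-trimethoxyphenyl gives a 1.0-fold lower number from compound 2 to compound 3 (0.01 log units; within the scatter) and does not separate the two groups, so the two further methoxy groups bring no change that can be read in this cell assay. No measurement on these compounds accounts for either step.

On these data alone, it remains open whether a chloro or fluoro group in place of the bromine would hold the number of compound 1 or move it. Also open, as far as these compounds go, is how an amine, a carboxylic acid or a longer alkyl chain in place of 3-bromophenyl would read.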